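A few compounds are considered here, and "the series" means these few. Any claim that something is new, unique, unknown or untested is made for them only; others in the source may bear on it.

Going by the values given here, in a functional assay on KBVIN cells (Homo sapiens) for antiproliferative activity, read by sulforhodamine B assay, with a stated time of 3 days (a lower number here means that less compound is needed, a higher number that more compound is needed for the effect), compound 1 (`CCCC1=C(OCC(C)C)C(CCC)(CCC)C(=O)/C(=C(O)\C=C\c2ccccc2)C1=O`) gives 4.1 uM and holds the lower of the two numbers measured so far. Compound 2 (`CCCCC1=C(OC)C(CCCC)(CCCC)C(=O)/C(=C(O)\C=C\c2ccccc2)C1=O`) gives 8.6 uM and so needs more compound for the same effect, a gap that lies beyond the usual scatter. Compound 3 (`CCCOC1=C(CCC)C(=O)/C(=C(O)/C=C/c2ccccc2)C(=O)C1(CCC)CCC`) has not yet been measured. It differs from compound 1 by one small edit (hydrogen in place of methyl on a saturated chain carbon bound to two saturated chain carbons): hydrogen in place of methyl on a saturated chain carbon bound to two saturated chain carbons, which turns isobutoxy into propoxy. Among the compounds with values here, no measured pair of compounds isolates this change, so any forecast is loose. Within the data shown here, the only anchors are compound 1 at 4.1 uM and compound 2 at 8.6 uM and these two differ in more than this one place. The expected step is small (a 1.2-fold higher number from compound 1 to compound 3 (0.09 log units; within the scatter)), toward a slightly higher number in this assay and probably not beyond the scatter. For compound 3 the estimated value is 5 uM (expected range 2.5 uM to 10 uM).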

Compound 3, concentration for half-maximal effect: 2.4 uM
The estimate for compound 3 lay 2.1-fold (0.32 log units) above the measured number, and the stated range ends above it.
By their numbers in this assay, from the lowest: compounds 3 and 1 (each within the scatter of the next); then compound 2.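

In this assay, going from isobutoxy to propoxy, with hydrogen in place of methyl on a saturated chain carbon bound to two saturated chain carbons, gives a 1.7-fold lower number from compound 1 to compound 3 (0.23 log units; within the scatter). This is the first pair shown that differs in one place only, so it is the first direct look at this part of the molecule. The step lies within the usual scatter, so compound 1 and compound 3 cannot be told apart, and this methyl can be removed with no loss that this read-out can detect. No measurement shown explains why the number holds when this methyl is removed.

This single pair tests only one small trim of the chain, so it cannot show how far the position tolerates change in general. From the compounds shown here alone, a longer chain such as hexyloxy, or an amine or a carboxylic acid at the end of the chain, remains open, and any of these could move the number well beyond the scatter or leave it where it is.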